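Swapping the aryl group on the triazole: compound 4

The compounds below may be only part of what the source reports. "The series", "measured", "known", "first", "only" and "open" are said of these compounds alone.

Of the compounds shown here, three have been measured in a functional assay on HepG2 cells (Homo sapiens) for antiproliferative activity, read by MTT assay, with a stated time of 48 h; a lower number here means a stronger inhibitor, a higher number a weaker inhibitor.
Compound 1, `Cc1cccc(-n2nncc2CN2C(=O)C3(C(C#N)=C(N)Oc4c(N)cc5nc6ccccc6nc5c43)c3ccccc32)c1`, gives only a limit, > 50000 nM.
Compound 2, `CCOc1ccccc1-n1nncc1CN1C(=O)C2(C(C#N)=C(N)Oc3c(N)cc4nc5ccccc5nc4c32)c2ccccc21`, gives 30500 nM.
Compound 3, `COc1ccc(OC)c(-n2nncc2CN2C(=O)C3(C(C#N)=C(N)Oc4c(N)cc5nc6ccccc6nc5c43)c3ccccc32)c1`, gives 45100 nM.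

Compound 3 holds the highest of the two real numbers, but its nearest neighbour is close: a 1.5-fold higher number from compound 2 to compound 3 (0.17 log units; within the scatter). Compound 1 yields no number at all, only (the limit of > 50000 nM in this assay, at which 1 of the 3 values shown sits), so it cannot be ranked against the other two.

Compound 4, `Cc1ccc(-n2nncc2CN2C(=O)C3(C(C#N)=C(N)Oc4c(N)cc5nc6ccccc6nc5c43)c3ccccc32)cc1Cl`, is not yet measured. It differs from compound 3 in one place: 3-chloro-4-methylphenyl in place of 2,5-dimethoxyphenyl on an aromatic nitrogen.

Every measured step at this same position on the shared core stayed small. an at least 1.6-fold lower number from compound 1 to compound 2 (0.21 log units; that floor lies within the scatter) and an at least 1.1-fold lower number from compound 1 to compound 3 (0.04 log units; that floor lies within the scatter) are both only floors set by the limit of compound 1, and a 1.5-fold higher number from compound 2 to compound 3 (0.17 log units; within the scatter) is within the scatter. Three different aryl groups on this aromatic nitrogen therefore gave no step beyond the scatter, which suggests that another aryl group should behave alike. For compound 4 the expected step is a 1.1-fold lower number from compound 3 to compound 4 (0.05 log units; within the scatter). The estimate for compound 4 in this assay is therefore 40000 nM, with a range from 18000 nM to 80000 nM.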

Compound 4, half-maximal inhibitory concentration: > 50000 nM
Compound 4 was reported as a limit (the forecaster's own chance of this, stated with the estimate: 35%); middle value at least 1.2-fold (0.09 log units) from the limit.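

With compound 4, a second aryl group on this aromatic nitrogen gives only a limit and not a number: the limit of > 50000 nM in this assay, at which 2 of the 4 values shown sit.

The steps to compound 4 are floors, an at least 1.1-fold higher number from compound 3 to compound 4 (0.04 log units; that floor lies within the scatter) and an at least 1.6-fold higher number from compound 2 to compound 4 (0.21 log units; that floor lies within the scatter), so the true steps may be larger, while the step between compound 1 and compound 4, two limits, cannot be read. Among the four compounds, the two aryl groups that carry ethoxy or methoxy, in compound 2 and compound 3, give numbers, and the two without oxygen, in compound 1 and compound 4, give limits, though no step printed here lies beyond the scatter.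

From the compounds shown here alone, it stays open how far the true values of compound 1 and compound 4 lie past the limit. Going by these compounds, it also stays open whether an aryl group carrying an amine or a carboxylic acid on this nitrogen would give a much lower number.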